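Cyclopropyl for 3-hydroxycyclobutyl on a long-lived compound

The source may hold more compounds than are shown below. What is called first, only, known or untested is meant among the compounds shown, and "the series" means these compounds.

In an ADME assay on microsomes from liver (Mus musculus) for metabolic stability, read by LC-MS, using NADPH, with a stated time of 10 min, tested at 10 uM (on this read-out lower numbers stand for a shorter-lived compound and higher numbers for a longer-lived compound), compound 1 `Nc1ncnc2c1c(Oc1cc(C(F)(F)F)ccn1)nn2C1CC1` gives > 2.41 h, which is a limit and not a number. Compound 2 `N#Cc1ccnc(Oc2nn([C@H]3C[C@H](O)C3)c3ncnc(N)c23)c1` gives > 2.41 h, also a limit. Compound 2 therefore has no exact half-life and stands at the limit of > 2.41 h in this assay, at which 2 of the 2 values shown sit. Compound 3 `N#Cc1ccnc(Oc2nn(C3CC3)c3ncnc(N)c23)c1` brings one structural change, cyclopropyl in place of 3-hydroxycyclobutyl on an aromatic nitrogen. Within the data shown here, no measured step is available as a guide, so the expected change in this assay is none beyond the usual scatter, with an estimated step that the limit leaves unreadable from compound 2 to compound 3. Compound 3 is expected to show a half-life of 2.5 h, within an estimated range of 1.2 h to 5 h.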

Compound 3, half-life: > 2.41 h
Compound 3: no number, only a limit; the forecaster's own chance of this, stated with the estimate: 65%; the middle value lies beyond the limit too.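

No step can be read between compound 3 and either compound 1 or compound 2, since each result is a limit and not a number: the limit of > 2.41 h in this assay, at which 3 of the 3 values shown sit.

As far as these compounds go, the true half-lives of all three compounds stay open, and so does any effect of either swap, cyclopropyl for 3-hydroxycyclobutyl or cyano for trifluoromethyl.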